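The source may hold more compounds than are shown below. What is called first, only, known or untested is meant among the compounds shown, and "the series" means these compounds.

Compound 1, `CC(C)C[C@H](NC(=O)[C@]1(Cc2ccccc2)CCN1C(=O)OCc1ccccc1)C(N)=O`: in an ADME assay on HELF cells (Homo sapiens) for cytotoxicity, with a stated time of 3 days (a higher number here means that more compound is tolerated, a lower number that less compound is tolerated), compound 1 gives 50000 nM.
Compound 2, `C[C@H](NC(=O)[C@@]1(Cc2ccccc2)CCN1C(=O)OCc1ccccc1)C(=O)NC(C)(C)C`: in this assay compound 2 gives only the assay limit > 100000 nM.
Compound 3, `C[C@H](NC(=O)[C@@]1(Cc2ccccc2)CCN1C(=O)OCc1ccccc1)C(=O)NCc1ccccc1`: in this assay compound 3 gives 42000 nM.

Compound 3 holds the lowest of the two numbers shown, with compound 1 close by and within the scatter of it; compound 2 sits at the limit (the limit of > 100000 nM in this assay, at which 1 of the 3 values shown sits). Among the compounds with values here, the one measured step, an at least 2.3-fold lower number from compound 2 to compound 3 (0.37 log units; beyond the scatter), swaps a group on the amide-type nitrogen and moves the number modestly downward.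

Compound 4, `CC(C)C[C@H](NC(=O)[C@@]1(Cc2ccccc2)CCN1C(=O)OCc1ccccc1)C(N)=O`, arises from compound 3 by 1-carbamoyl-3-methylbutyl in place of 1-(benzylcarbamoyl)ethyl on an amide-type nitrogen. Compound 1 already carries this same 1-carbamoyl-3-methylbutyl group on its amide-type nitrogen, and its number lies within the scatter of compound 3. Within the data shown here, no measured step covers this exact exchange, so the expectation rests on the closeness of compound 1 and compound 3. Compound 4 is therefore expected to show about a 1.2-fold higher number from compound 3 to compound 4 (0.08 log units; within the scatter), that is no change beyond the scatter. The estimate for compound 4 is 50000 nM, within 25000 nM to 100000 nM.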

Compound 4, half-maximal cytotoxic concentration: 66000 nM
The estimate for compound 4 lay 1.3-fold (0.12 log units) below the measured number; the range from low to high includes it.
By their numbers in this assay, from the lowest: compounds 3, 1 and 4 (each within the scatter of the next). At a limit, above all of these: compound 2.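

Putting 1-carbamoyl-3-methylbutyl in place of 1-(benzylcarbamoyl)ethyl on the amide-type nitrogen gives a 1.6-fold higher number from compound 3 to compound 4 (0.20 log units; within the scatter), so in this assay this exchange moves the number by no more than repeat measurements would. The new pair also isolates the configuration at the saturated ring carbon, and a 1.3-fold higher number from compound 1 to compound 4 (0.12 log units; within the scatter) shows that reversing it as drawn has no effect that can be told from the scatter, as the comparison is a clean one: the fact that compounds 1 and 4 differ only in the configuration as drawn The remaining step, an at least 1.5-fold lower number from compound 2 to compound 4 (0.18 log units; that floor lies within the scatter), starts from a limit and so gives only a floor: the limit of > 100000 nM in this assay, at which 1 of the 4 values shown sits.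

Going by these compounds, it remains open whether a carboxylic acid or an amine at the end of a longer chain on this nitrogen would shift the number beyond the scatter. The one configuration pair shown carries 1-carbamoyl-3-methylbutyl, so the effect of reversing the ring carbon with 1-(benzylcarbamoyl)ethyl in that place also stays open.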